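Changing the Outer Ring on the Alkyne Arm

The source may hold more compounds than are shown below. What is called first, only, known or untested is meant among the compounds shown, and "the series" means these compounds.

Three compounds have been measured in an assay on Sf9 cells for inhibition of mitogen-activated protein kinase kinase kinase 14 variant S549D (Homo sapiens), with a stated time of 30 min, in the presence of a further agent that is not named here; a higher number here means a weaker inhibitor, a lower number a stronger inhibitor:

compound 1, `C=CC(=O)NCCCCc1ccc2ncn(-c3ccnc(N)n3)c2c1`: 501000 nM
compound 2, `CC(=O)NCCCCc1ccc2ncn(-c3ccnc(N)n3)c2c1`: 398000 nM
compound 3, `C#Cc1cccc(C#Cc2ccc3ncn(-c4ccnc(N)n4)c3c2)n1`: 3160 nM

Compounds 1 and 2 share an amide-bearing chain on the common core and differ only at the carbonyl carbon, where a 1.3-fold lower number from compound 1 to compound 2 (0.10 log units; within the scatter). Compound 3 carries instead a rigid arm made of a triple bond and an outer aromatic ring, and it stands apart: its number is the lowest of the three, with compound 2 nearest and compound 1 furthest, both gaps far beyond the scatter.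

Compound 4, `Cc1ccnc(C#Cc2ccc3ncn(-c4ccnc(N)n4)c3c2)n1`, keeps the arm of compound 3 but changes the outer ring: a group of 7 heavy atoms (5 carbon, 2 nitrogen; one six-membered aromatic ring with 2 hetero atoms) in place of a group of 8 heavy atoms (7 carbon, 1 nitrogen; one six-membered aromatic ring with 1 hetero atom), on a triple-bonded carbon

For the measured compounds named here, the only measured step, from compound 1 to compound 2, concerns the amide chain and touches nothing on the alkyne arm, so it offers no guide to this change. What remains is that compound 3 shows the arm itself to be compatible with a low number. Going by the values given here, with no step to copy, the expectation is a modest shift at most from compound 3 to compound 4, a 1.6-fold higher number from compound 3 to compound 4 (0.20 log units; within the scatter), in no firmly known direction. Compound 4 is therefore estimated at 5000 nM, within a range of 1000 nM to 25000 nM.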

Compound 4, half-maximal inhibitory concentration: 1580 nM
Compound 4: the middle estimate sits 3.2-fold (0.50 log units) above what was measured, and the stated range covers the measured number.
By their numbers in this assay, from the lowest: compounds 4 and 3 (each within the scatter of the next); then compounds 2 and 1 (each within the scatter of the next).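

In this assay, placing 4-methylpyrimidin-2-yl on the triple-bonded carbon gives a 2.0-fold lower number from compound 3 to compound 4 (0.30 log units; within the scatter), so the two compounds cannot be told apart in this measurement. For the compounds shown here, this is the first look at a change on the alkyne arm, and it shows that this position can take a quite different outer group without a shift beyond the scatter: the ring gains a second hetero atom, and the triple bond of the group that leaves has no counterpart in the group that enters. The data shown offer no independent measurement that could explain why these two groups give such similar numbers.

Several things changed together in this single step, so the separate contributions of the methyl group, the extra ring nitrogen and the lost triple bond remain unknown. Going by these compounds, it also remains open how this position would respond to a group of another kind on the triple-bonded carbon, such as a plain phenyl ring, or to an outer ring bearing an amine, a carboxylic acid or a longer chain.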